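A few compounds are considered here, and "the series" means these few. Any claim that something is new, unique, unknown or untested is made for them only; others in the source may bear on it.

Compound 1 `CCCOc1cc(-c2ccccc2)nc2ccccc12`: > 10 ug/mL
Compound 2 `CC(C)COc1cc(-c2ccccc2)nc2ccccc12`: > 10 ug/mL
Compound 3 `CS(=O)(=O)Oc1cc(-c2ccccc2)nc2ccccc12`: not yet measured

Both entries were obtained in a functional assay on L1210 (1565) cells (Mus musculus) for cytotoxicity (a lower number here means that less compound is needed, a higher number that more compound is needed for the effect), and neither is a number. Compound 2 stands at > 10 ug/mL, which is a limit. Compound 1 stands at > 10 ug/mL, which is also a limit. Among the measured compounds shown here, the series so far offers only (the limit of > 10 ug/mL in this assay, at which 2 of the 2 values shown sit).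

Compound 3 differs from compound 2 as follows: methylsulfonyl in place of isobutyl on an oxygen on an aromatic ring.

For the measured compounds named here, the one measured step, a step that the two limits leave unreadable from compound 1 to compound 2, changes a chain carbon rather than the group on the oxygen. It gives no size to carry over, so no step beyond the scatter is expected in this assay, and no direction can be assigned. The expected step is a step that the limit leaves unreadable from compound 2 to compound 3. A further limit is the likeliest result. For compound 3 the estimate is 12 ug/mL. The expected range runs from 5 ug/mL to 30 ug/mL.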

Compound 3, half-maximal effective concentration: 6.04 ug/mL
Estimate against measurement, compound 3: 2.0-fold (0.30 log units) above; the range from low to high includes it.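

In this assay, among the compounds shown here, compound 3 gives 6.04 ug/mL, the first value that is a number and not a limit, so a group on this oxygen can bring the read-out into the measurable range. Methylsulfonyl in place of isobutyl gives an at least 1.6-fold lower number from compound 2 to compound 3 (0.21 log units; that floor lies within the scatter), and methylsulfonyl in place of propyl gives an at least 1.6-fold lower number from compound 1 to compound 3 (0.21 log units; that floor lies within the scatter); both sizes are floors only, and the step from compound 1 to compound 2 cannot be read. The two alkyl groups therefore remain unplaced relative to methylsulfonyl, with their values still at the assay limit: the limit of > 10 ug/mL in this assay, at which 2 of the 3 values shown sit.

Open, on these data alone, is how far compound 1 and compound 2 really lie from compound 3 in this assay. Also open, as far as these compounds go, is whether a phenylsulfonyl or an acetyl group on the same oxygen gives a number in this assay.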